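Varying the amide-linked aryl group: expectation for compound 4

The source may hold more compounds than are shown below. What is called first, only, known or untested is meant among the compounds shown, and "the series" means these compounds.

Measured compounds:
compound 1, `COc1cccc(NC(=O)c2ccc(OC)c(Nc3nccc(-c4cccnc4)n3)c2)c1`, 93100 nM
compound 2, `COc1ccc(C(=O)Nc2cc(Br)cc(C(F)(F)F)c2)cc1Nc1nccc(-c2cccnc2)n1`, 215000 nM
compound 3, `COc1ccc(C(=O)Nc2ccc(F)c(Cl)c2)cc1Nc1nccc(-c2cccnc2)n1`, "not determined" (no result reported)

In a functional assay on K562 cells (Homo sapiens) for antiproliferative activity, read by MTT assay, with a stated time of 48 h (a lower number here means a stronger inhibitor, a higher number a weaker inhibitor), compound 1 gives 93100 nM, and in the same assay compound 2 gives 215000 nM. For compound 3 the entry in this assay reads "not determined" (no result reported), so its standing cannot be placed. Compound 4, `COc1ccc(C(=O)Nc2cccc(C(C)=O)c2)cc1Nc1nccc(-c2cccnc2)n1`, differs from compound 3 by 3-acetylphenyl in place of 3-chloro-4-fluorophenyl on an amide-type nitrogen. Going by the values given here, the only measured step that bears on this, a 2.3-fold higher number from compound 1 to compound 2 (0.36 log units; beyond the scatter), also exchanges the group on the amide-type nitrogen and was modest; both measured compounds sit at weak potency. A step of similar or smaller size, in either direction, is therefore expected for compound 4 in this assay, leaving it weak. Compound 4 is estimated at 120000 nM, with a range of 40000 nM to 350000 nM.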

Compound 4, half-maximal inhibitory concentration: 237000 nM
Compound 4: middle estimate off by 2.0-fold (0.30 log units), on the low side; the measured number falls inside the stated range.
By their numbers in this assay, from the lowest: compound 1; then compounds 2 and 4 (each within the scatter of the next).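

In this assay the change to 3-acetylphenyl on the amide-type nitrogen gives a 1.1-fold higher number from compound 2 to compound 4 (0.04 log units; within the scatter) and so does not separate this group from 3-bromo-5-(trifluoromethyl)phenyl. Acetyl in place of methoxy on the aromatic carbon gives a 2.5-fold higher number from compound 1 to compound 4 (0.41 log units; beyond the scatter) and is a modest step toward weaker activity, so a single change on this aryl group can move the number beyond the scatter. Nothing measured here gives a reason for either step. On these data alone, whether an amine or a carboxylic acid on this aryl group would bring the number down remains open. As far as these compounds go, the standing of compound 3 also remains open, as it has no result.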